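The source may hold more compounds than are shown below. What is called first, only, known or untested is meant among the compounds shown, and "the series" means these compounds.

Of the compounds shown here, two built on one shared core have so far been tested in a functional assay on the whole organism (Tail, strain ICR) with Mus musculus as the target, in the tail flick test, with a stated time of 90 min, at a dose of 25 umol/kg by the oral route; on this read-out lower numbers stand for a weaker effect and higher numbers for a stronger effect at the one dose given. Compound 1, `NCCCC[C@H](NC(=O)CN(c1nc(Cl)nc2[nH]cnc12)C1CC1)C(=O)OCc1ccccc1`, gives 35.3%. Compound 2, `O=C(O)CC[C@H](NC(=O)CN(c1nc(Cl)nc2[nH]cnc12)C1CC1)C(=O)O`, gives 44.7%. Within the data shown here, of these two numbers the one from compound 2 is the higher, but its only neighbour, compound 1, sits at a gap that falls within the usual scatter of repeated measurements of this kind, so the two values cannot be told apart. Among the measured compounds shown here, no pair of measured compounds differs in a single place, so no measured single-place step is available.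

Compound 3, `NCCCC[C@H](NC(=O)CN(c1nc(Cl)nc2[nH]cnc12)C1CC1)C(=O)O`, has not yet been tested. It differs from compound 2 in one place: 2-aminoethyl in place of carboxy on a saturated chain carbon, three bonds along the chain from an amide-type nitrogen and a carbonyl carbon. Cut one bond further out, the same change reads as 1,3-dicarboxypropyl to 5-amino-1-carboxypentyl.

For the measured compounds named here, with no measured step to lean on, and with compound 1 at 35.3% and compound 2 at 44.7% lying close together, the expected step is a number 4.7 percentage points lower from compound 2 to compound 3 (within the scatter), that is, nothing beyond the scatter in either direction. Compound 3 is therefore estimated at 40%, within a range from 20% to 60%.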

Compound 3, a percentage reported as activity, at one dose (the size of the read-out at that dose, not a potency): 28.8%
Estimate against measurement, compound 3: 11.2 percentage points above; low and high end bracket the measured number.
By their numbers in this assay, from the lowest: compounds 3, 1 and 2 (each within the scatter of the next, the first and the last beyond it).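

In this assay, the step with 2-aminoethyl in place of carboxy on the saturated chain carbon is a number 15.9 percentage points lower from compound 2 to compound 3 (beyond the scatter). Among these compounds, this modest step is the first single-place comparison, and it shows that the read-out at this one dose does respond to a change at this position. By contrast, putting hydrogen in place of benzyl on an oxygen next to a carbonyl group gives a number 6.5 percentage points lower from compound 1 to compound 3 (within the scatter), so on the amine-bearing chain the two forms cannot be told apart. No measurement shown here explains either step.

The change at the chain alters its length and its end group together, reading as 2-carboxyethyl to 4-aminobutyl, so it remains open which of the two accounts for the step; a longer chain ending in a carboxylic acid, or a shorter chain ending in an amine, would separate them. As far as these compounds go, it also remains open whether a benzyl group on the oxygen of a carboxy group would leave the number as little changed on the chain of compound 2 as it does on the chain of compound 3.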